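Swapping an Alkyl for an Amide on the Ring Nitrogen

The source may report more compounds than this note shows. Statements on the series, on what has been measured and on what is new or still open speak of the compounds shown alone.

compound 1: `CN1CCc2nc(C#Cc3cccc(F)c3)sc2C1`, > 10000 nM
compound 2: `CC(C)CN1CCc2nc(C#Cc3ccccc3)sc2C1`, > 10000 nM

In an assay on HEK293 cells for positive allosteric modulation of metabotropic glutamate receptor 5 (Homo sapiens), read by FLIPR, with a stated time of 1 h (on this read-out higher numbers stand for an effect only at larger amounts of compound and lower numbers for an effect already at smaller amounts), compound 1 gives only a limit, > 10000 nM. Compound 2 also stops at the limit of this assay, > 10000 nM. Both values sit at the limit of > 10000 nM in this assay, at which 2 of the 2 values shown sit, so no number is known for compound 2. Compound 3, `O=C(C1CCCC1)N1CCc2nc(C#Cc3ccccc3)sc2C1`, differs from compound 2 by cyclopentylcarbonyl in place of isobutyl on an amine nitrogen in a ring. Among the compounds with values here, no step between measured compounds exists here, so the change cannot be read from data. Compound 3 is nevertheless expected to give a measurable value, with an estimated step of an at least 10-fold lower number from compound 2 to compound 3 (1.00 log units; beyond the scatter) toward smaller amounts, beyond the scatter. Compound 3 is estimated at 1000 nM, between 100 nM and 10000 nM.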

Compound 3, half-maximal effective concentration: 19 nM
Compound 3: middle estimate off by 53-fold (1.72 log units), on the high side, and the stated range ends above it.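

On this amine nitrogen in a ring, cyclopentylcarbonyl in place of isobutyl brings an at least 520-fold lower number from compound 2 to compound 3 (2.72 log units; beyond the scatter) in this assay and turns a compound without a measurable number into one with a clear effect. The position is therefore highly sensitive to what it carries. Compound 2 gives only a limit, so the true size of this step stays unknown: the limit of > 10000 nM in this assay, at which 2 of the 3 values shown sit.

The change adds a carbonyl and a ring together, so the compounds shown do not separate the two. A cyclopentylmethyl group or a 3-methylbutanoyl group on the same nitrogen would tell them apart.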